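From ethylamino to ethoxy on a shared core

This account rests on a few compounds, and the source may have more. Where it says the series, first, only, none or still open, it means among the compounds named here.

Measured in an ADME assay on GM00637 cells (Homo sapiens) for cytotoxicity, read by MTT assay, with a stated time of 72 h; on this read-out lower numbers stand for stronger inhibition and higher numbers for weaker inhibition:
Compound 1 `CNc1cc2nc(-c3ccccc3)nn(-c3ccccc3)c-2cc1=O`: 930 nM
Compound 2 `CCNc1cc2nc(-c3ccccc3)nn(-c3ccccc3)c-2cc1=O`: 240 nM
Compound 3 `CC(=O)Nc1cc2nc(-c3ccccc3)nn(-c3ccccc3)c-2cc1=O`: > 5000 nM, a limit of the assay

Going by the values given here, compound 2 gives the lowest number so far, 240 nM. The nearest exact value lies one modest step away: a 3.9-fold lower number from compound 1 to compound 2 (0.59 log units; beyond the scatter). Putting acetyl on the nitrogen in place of ethyl moves the number much further: an at least 20-fold higher number from compound 2 to compound 3 (1.31 log units; beyond the scatter). Acetyl in place of methyl points the same way: an at least 5.3-fold higher number from compound 1 to compound 3 (0.73 log units; beyond the scatter).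

Compound 4 `CCOc1cc2nc(-c3ccccc3)nn(-c3ccccc3)c-2cc1=O` keeps the shared core and changes a single group: ethoxy in place of ethylamino on an aromatic carbon. In words, this is ethoxy in place of ethylamino on an aromatic carbon. Among the compounds with values here, no measured step replaces this nitrogen with oxygen, so the guidance is indirect. The ethyl chain stays, which argues against a loss as large as the acetyl step. Still, an at least 20-fold higher number from compound 2 to compound 3 (1.31 log units; beyond the scatter) shows that this assay can respond strongly to a change at this nitrogen, so a modest move toward weaker inhibition seems more likely than a further gain. The expected change is a 2.5-fold higher number from compound 2 to compound 4 (0.40 log units; beyond the scatter). For compound 4 the estimated value is 600 nM, with an expected range from 150 nM to 2500 nM.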

Compound 4, half-maximal inhibitory concentration: > 5000 nM
Compound 4: a limit, no number (the forecaster's own chance of this, stated with the estimate: 10%); middle value at least 8.3-fold (0.92 log units) from the limit.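

Keeping the ethyl chain does not keep the activity, as the change of a single atom gives a large step: an at least 20-fold higher number from compound 2 to compound 4 (1.31 log units; beyond the scatter). In this small set, then, the low number of compound 2 depends on the nitrogen that carries the chain and not on the chain alone, and the ethoxy group also loses out against the shorter methylamino group: an at least 5.3-fold higher number from compound 1 to compound 4 (0.73 log units; beyond the scatter). The loss of the hydrogen on that nitrogen cannot be the whole story, since compound 3 goes against that reading by keeping the amide hydrogen and still not giving a number, and the step between compound 3 and compound 4 cannot be read, as both are limits and not numbers: the limit of > 5000 nM in this assay, at which 2 of the 4 values shown sit.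

On these data alone, whether the number keeps falling with a longer chain on the nitrogen, such as propyl, stays open, as does what a plain amine with no chain at all would give on the shared core. As far as these compounds go, how far past the limit compound 3 and compound 4 really lie also stays unknown, so neither can be ranked against the other.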